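The source may report more compounds than this note shows. Statements on the series, on what has been measured and on what is new or still open speak of the compounds shown alone.

Compound 1 `C[C@H](NC(=O)c1cc(Cl)ccc1O)C(=O)Nc1ccc(C(F)(F)F)cc1` — in a functional assay on K562 cells (Homo sapiens) for cytotoxicity, with a stated time of 72 h (a lower number here means a stronger inhibitor, a higher number a weaker inhibitor), compound 1 gives > 12500 nM, a limit of the assay.
Compound 2 `C[C@H](NC(=O)c1ccc(Cl)cc1O)C(=O)Nc1ccc(C(F)(F)F)cc1` — in this assay compound 2 gives > 12500 nM, a limit of the assay.
Compound 3 `CC(C)[C@H](NC(=O)c1cc(Cl)ccc1O)C(=O)Nc1ccc(Cl)c(Cl)c1` — in this assay compound 3 gives > 10000 nM, a limit of the assay.

Compound 1 stands only as a limit in this assay, and the two other values shown are limits as well: one sits at the limit of > 10000 nM in this assay, at which 1 of the 3 values shown sits, two sit at the limit of > 12500 nM in this assay, at which 2 of the 3 values shown sit. Within the data shown here, the one single-point step among the measured compounds, a step that the two limits leave unreadable from compound 1 to compound 2, is unreadable, since both ends are limits. Compound 4 `Cc1ccc(NC(=O)[C@H](C)NC(=O)c2cc(Cl)ccc2O)cc1` differs from compound 1 by methyl in place of trifluoromethyl on an aromatic carbon. Among the measured compounds shown here, no measured step bears directly on this exchange, and the only measured step gives no size at all, so there is no basis for expecting a change beyond the scatter in either direction. Given that compound 1 reaches only > 12500 nM, compound 4 is expected to show a step that the limit leaves unreadable from compound 1 to compound 4, that is, none that can be read. The estimate for compound 4 in this assay is therefore 15000 nM, within a range from 5000 nM to 50000 nM, and most likely the assay will again report only a limit.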

Compound 4, half-maximal inhibitory concentration: > 10000 nM
Compound 4: no number, only a limit; the forecaster's own chance of this, stated with the estimate: 80%; the middle value is on the limit's open side.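

Compound 4 gives > 10000 nM in this assay, which is a limit of the assay. With compound 1 also standing only as a limit, no step can be read between them. The compounds shown leave open what actual value any of them would reach and whether methyl in place of trifluoromethyl changes it.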